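The compounds below may be only part of what the source reports. "The series", "measured", "known", "first", "only" and "open" are said of these compounds alone.

Of the compounds shown here, three sharing one core have been tested in a functional assay on SW480 cells (Homo sapiens) for cytotoxicity, read by MTT assay, with a stated time of 48 h; a higher number here means a weaker inhibitor, a lower number a stronger inhibitor. Compound 1 `Cc1cccc(Cn2cc(COc3ccc4c(=O)ccoc4c3)nn2)c1` carries a 3-methylphenyl on a saturated chain carbon bound to an aromatic nitrogen, and in this assay compound 1 gives 11700 nM. Compound 2 `Cc1ccccc1Cn1cc(COc2ccc3c(=O)ccoc3c2)nn1` carries a 2-methylphenyl in that place. In this assay compound 2 reaches only a limit of the assay, > 100000 nM, not a number. Compound 3 `C#CCOc1ccc2c(=O)ccoc2c1` is a smaller fragment of the same core. In this assay compound 3 likewise reaches only a limit, > 100000 nM. Compound 2 therefore sits at the weak end of what is known: the step of an at least 8.5-fold higher number from compound 1 to compound 2 (0.93 log units; beyond the scatter) is beyond the scatter, and the limit of > 100000 nM in this assay, at which 2 of the 3 values shown sit, marks where compound 2 stands.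

Compound 4 `O=c1ccoc2cc(OCc3cn(Cc4cccc(Cl)c4)nn3)ccc12` differs from compound 2 by 3-chlorophenyl in place of 2-methylphenyl on a saturated chain carbon bound to an aromatic nitrogen. For the measured compounds named here, the only measured step bearing on this change is an at least 8.5-fold higher number from compound 1 to compound 2 (0.93 log units; beyond the scatter), a shift of at least modest size that favours 3-methylphenyl over 2-methylphenyl; 3-chlorophenyl is closer in pattern to the former, while the exchange of methyl for chlorine is tested by no measured pair here. Compound 4 is therefore expected to move back toward stronger inhibition, an at least 11-fold lower number from compound 2 to compound 4 (1.04 log units; beyond the scatter). Compound 4 is estimated at 9000 nM, between 2500 nM and 45000 nM.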

Compound 4, half-maximal inhibitory concentration: 12900 nM
Compound 4: the middle estimate sits 1.4-fold (0.16 log units) below what was measured; the range from low to high includes it.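

The change from 2-methylphenyl to 3-chlorophenyl brings back a measurable value in this assay, with an at least 7.7-fold lower number from compound 2 to compound 4 (0.88 log units; beyond the scatter). Chloro and methyl on the same aromatic carbon cannot be told apart, with a 1.1-fold higher number from compound 1 to compound 4 (0.04 log units; within the scatter), so this comparison shows that the two groups give matching results at this place, something the earlier compounds could not show. Compound 2 remains a limit and not a number, so the first step gives only a smallest possible size: the limit of > 100000 nM in this assay, at which 2 of the 4 values shown sit.

From the compounds shown here alone, what a methoxy, an amine or a carboxylic acid would do in place of the chloro remains open. So does whether a plain phenyl, with neither chloro nor methyl, would give a stronger or a weaker number.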